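The compounds below may be only part of what the source reports. "The series", "measured", "known", "first", "only" and "open" are said of these compounds alone.

In an ADME assay on MIA PaCa-2 cells (Homo sapiens) for cytotoxicity, read by MTT assay, with a stated time of 72 h (on this read-out lower numbers stand for stronger inhibition and higher numbers for weaker inhibition), compound 1 `COc1ccc(OC)c(C2=C(c3cc(OC)c(OC)c(OC)c3)C(=O)CC2O[SiH2]C(C)(C)C)c1` gives > 100 ug/mL as a limit, not a number. Compound 2 `COc1ccc(C2=C(c3cc(OC)c(OC)c(OC)c3)C(=O)CC2O[SiH2]C(C)(C)C)cc1OC` gives > 100 ug/mL as a limit too. Within the data shown here, the only measured step is a step that the two limits leave unreadable from compound 1 to compound 2 and it offers no size to carry forward. It also sits elsewhere on the molecule than the change now in question. Compound 3 `COc1ccc(OC)c(C2=C(c3cc(OC)c(OC)c(OC)c3)C(=O)CC2O)c1` departs from compound 1 by a hydrogen atom in place of a group of 5 heavy atoms (4 carbon, 1 silicon; no ring), on an oxygen on a saturated carbon and in no other way. Among the measured compounds shown here, no measured step covers this change, so its size rests on little. All the evidence so far is the limit of > 100 ug/mL in this assay, at which 2 of the 2 values shown sit, and a readable result could only lie towards stronger inhibition. The expected outcome is an at least 2.5-fold lower number from compound 1 to compound 3 (0.39 log units; beyond the scatter) in that direction, although a further limit remains quite possible. For compound 3 the estimate in this assay is 40 ug/mL with 6 ug/mL to 150 ug/mL as the expected range.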

Compound 3, half-maximal inhibitory concentration: > 100 ug/mL
Compound 3: a limit, no number (the forecaster's own chance of this, stated with the estimate: 40%); at least 2.5-fold (0.39 log units) between middle value and limit.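

No new step can be read: for compound 1 and compound 3 this assay gives only limits, not numbers, and the step between them stays unreadable: the limit of > 100 ug/mL in this assay, at which 3 of the 3 values shown sit. The compounds shown leave open whether any change to the shared core gives a readable number in this assay.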